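This account rests on a few compounds, and the source may have more. Where it says the series, first, only, none or still open, it means among the compounds named here.

Compound 1 `O=C(Nc1ccc(Oc2ccnc3[nH]ccc23)cc1)c1nn(-c2ccccc2)ccc1=O`: in a functional assay on PC-3 cells (Homo sapiens) for cytotoxicity, read by MTT assay, with a stated time of 72 h (a higher number here means a weaker inhibitor, a lower number a stronger inhibitor), compound 1 gives 15000 nM.
Compound 2 `Cn1ccc2c(Oc3ccc(NC(=O)c4nn(-c5ccc(Br)cc5)ccc4=O)cc3)ccnc21`: in this assay compound 2 gives 23000 nM.

For the measured compounds named here, of the two numbers, the one for compound 2 is the larger, but compound 1 lies within the usual scatter of it, so the two cannot be told apart in this assay. Going by the values given here, compound 1 and compound 2 differ in more than one place, so no single step connects them, and nothing more can be read from their pair than that their values are close. Compound 3 `Cn1ccc2c(Oc3ccc(NC(=O)c4nn(-c5ccccc5)ccc4=O)cc3)ccnc21` has not yet been measured. It differs from compound 2 in one place: hydrogen in place of bromo on an aromatic carbon. Among the compounds with values here, no measured pair shows this change on its own, so its effect is unknown here. On the two numbers available nothing points to a shift beyond the scatter, and the expected step of a 1.3-fold lower number from compound 2 to compound 3 (0.11 log units; within the scatter) in this assay is small, in no particular direction. Compound 3 is therefore estimated to give 18000 nM in this assay, expected to fall between 6000 nM and 50000 nM.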

Compound 3, half-maximal inhibitory concentration: 58200 nM
Compound 3: middle estimate off by 3.2-fold (0.51 log units), on the low side, and the stated range ends below it.
By their numbers in this assay, from the lowest: compounds 1 and 2 (each within the scatter of the next); then compound 3.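

In this assay, the change from 4-bromophenyl to phenyl can now be read on its own: hydrogen in place of bromo gives a 2.5-fold higher number from compound 2 to compound 3 (0.40 log units; beyond the scatter), so losing the bromo weakens the compound modestly. Methyl in place of hydrogen on the aromatic nitrogen also has a measured effect, a 3.9-fold higher number from compound 1 to compound 3 (0.59 log units; beyond the scatter), and it too points towards weaker inhibition. Read together, these steps show that the closeness of compound 1 and compound 2 hides two structural changes, each with an effect beyond the scatter, which run in opposite directions along the path through compound 3.

From the compounds shown here alone, whether chloro or methoxy at the bromo position, or an ethyl group on the nitrogen, would move the value further remains open. Nothing available here explains why either step occurs.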